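Biaryl terminus swap on the shared amide-nitrile core

The compounds below may be only part of what the source reports. "The series", "measured", "known", "first", "only" and "open" are said of these compounds alone.

Compound 3 `CC[C@@H](Nc1c(C#N)c(-c2ccc(-c3ccccc3COC)cc2)nc2cnccc12)C(N)=O` carries a 2-(methoxymethyl)phenyl on the outer ring of the shared core. Among the compounds with values here, in a physicochemical assay for lipophilicity, read by HPLC, at pH 7.5 (on this read-out lower numbers stand for lower lipophilicity and higher numbers for higher lipophilicity), compound 3 gives 2.6, the lowest of the three numbers so far: compound 1 `CC[C@@H](Nc1c(C#N)c(-c2ccc(-c3cccc(Cl)c3F)cc2)nc2cnccc12)C(N)=O` gives 3.1 and compound 2 `CC[C@@H](Nc1c(C#N)c(-c2ccc(-c3ccccc3C(C)C)cc2)nc2cnccc12)C(N)=O` gives 3.5. The steps that reach compound 3 both fall: a number 0.50 log units lower from compound 1 to compound 3 (beyond the scatter) and a number 0.90 log units lower from compound 2 to compound 3 (beyond the scatter). Between the two halogen- and alkyl-bearing variants, a number 0.40 log units higher from compound 1 to compound 2 (beyond the scatter).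

Compound 4 `CC[C@@H](Nc1c(C#N)c(-c2ccc(-c3cccc(Cl)c3)cc2)nc2cnccc12)C(N)=O` is not yet measured. Relative to compound 3 the change is 3-chlorophenyl in place of 2-(methoxymethyl)phenyl on an aromatic carbon.

Within the data shown here, the step that bears most directly is the one from compound 1 to compound 3, since compound 1 carries a 3-chloro-2-fluorophenyl and compound 4 a 3-chlorophenyl at the same place; running that step in reverse points to a rise of roughly the same size, with the step from compound 2 to compound 3 giving the outer bound. Compound 4 is therefore expected to rise beyond the scatter, a number 0.35 log units higher from compound 3 to compound 4 (beyond the scatter), landing near but not above compound 1. The estimate for compound 4 in this assay is 2.95, with a range from 2.6 to 3.3.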

Compound 4, distribution coefficient: 3.1
For compound 4 the middle estimate is 0.15 log units below the measured one; low and high end bracket the measured number.
By their numbers in this assay, from the lowest: compound 3; then compounds 1 and 4 (each within the scatter of the next); then compound 2.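

In this assay, within the data shown here, hydrogen in place of fluoro is the first change at this position that leaves the chloro in place and alters nothing else, and the read-out shows no change at the digits printed from compound 1 to compound 4 (within the scatter) for that pair. The 3-chlorophenyl terminus also stands apart from the other two termini by steps of the same size as those of the 3-chloro-2-fluorophenyl terminus, with a number 0.50 log units higher from compound 3 to compound 4 (beyond the scatter) and a number 0.40 log units lower from compound 2 to compound 4 (beyond the scatter), so within this set the fluoro makes no difference that can be read against either 2-(methoxymethyl)phenyl or 2-isopropylphenyl. Nothing at hand gives a reason for any of these numbers.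

No pair among the compounds shown carries the same group at two places on the outer ring, so it stays open whether the spread of values follows the identity of the group or where it sits. Going by these compounds, the chloro itself also stays open: the response of the read-out to a plain phenyl, or to an amine or a carboxylic acid at that place on the outer ring, cannot be told from these compounds.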